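The source may hold more compounds than are shown below. What is called first, only, known or untested is meant among the compounds shown, and "the series" means these compounds.

Compound 1 `O=C(CCCc1cccs1)N[C@@H]1[C@@H](O)[C@H](n2cnc3c(NC4CCCC4)ncnc32)O[C@@H]1CO`: 0.69 nM
Compound 2 `C[C@H]1O[C@@H](n2cnc3c(NC4CCCC4)ncnc32)[C@H](O)[C@H]1NC(=O)CCCc1cccs1`: 0.7 nM

Both numbers come from an assay on isolated protein with adenosine receptor A1 (Rattus norvegicus) as the target; on this read-out higher numbers stand for weaker inhibition and lower numbers for stronger inhibition. Among the compounds with values here, the only measured step, a 1.0-fold higher number from compound 1 to compound 2 (0.01 log units; within the scatter), leaves the two compounds within the usual scatter of this assay, so compound 2 and compound 1 cannot be told apart on these numbers. Compound 3 `C[C@H]1O[C@@H](n2cnc3c(NC4CCCC4)ncnc32)[C@H](O)[C@H]1NC(=O)C1(c2ccccc2)CCCC1` is not yet measured; it differs from compound 2 by 1-phenylcyclopentyl in place of 3-(thiophen-2-yl)propyl on a carbonyl carbon. No measured step touches this part of the molecule, so nothing shown bears on the change directly. Compound 3 is expected to give 3 nM, within 0.7 nM to 15 nM. That expectation amounts to a 4.3-fold higher number from compound 2 to compound 3 (0.63 log units; beyond the scatter) in this assay.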

Compound 3, inhibition constant: 0.84 nM
Compound 3: the middle estimate sits 3.6-fold (0.55 log units) above what was measured, within the range that was stated.
By their numbers in this assay, from the lowest: compounds 1, 2 and 3 (each within the scatter of the next).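

In this assay, 1-phenylcyclopentyl in place of 3-(thiophen-2-yl)propyl on the carbonyl carbon gives a 1.2-fold higher number from compound 2 to compound 3 (0.08 log units; within the scatter). This place in the molecule therefore takes an all-carbon group with two rings, one of them non-aromatic, as well as a chain ending in a sulfur-containing aromatic ring, with no difference that can be read. No evidence here explains why the two groups read alike.

Still open, from the compounds shown here alone, is whether a group carrying an amine or a carboxylic acid, or a short chain such as methyl, would also read alike on this carbonyl carbon.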